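Solubility across a benzyl-substituted furanylmethyl amine series

This account rests on a few compounds, and the source may have more. Where it says the series, first, only, none or still open, it means among the compounds named here.

Measured compounds:
compound 1, `Fc1ccc(Cc2ccc3c(NCCCNCc4ccco4)ccnc3c2)c(Cl)c1`, 4200 nM in a physicochemical assay for solubility, with a stated time of 18 h, at pH 7.4; a lower number here means a less soluble compound, a higher number a more soluble compound
compound 2, `Fc1ccc(Cc2ccc3c(NCCCNCc4ccco4)ccnc3c2)cc1`, 4200 nM

For the measured compounds named here, compound 2 stands level with compound 1 in this assay: the single known step, no change at the digits printed from compound 1 to compound 2 (within the scatter), shows no shift beyond the scatter.

Compound 3, `FC(F)(F)c1cccc(Cc2ccc3c(NCCCNCc4ccco4)ccnc3c2)c1`, is not yet measured. It differs from compound 2 by 3-(trifluoromethyl)phenyl in place of 4-fluorophenyl on a saturated chain carbon bound to an aromatic carbon. Going by the values given here, the only step on record, no change at the digits printed from compound 1 to compound 2 (within the scatter), is the nearest guide, and it was flat. The present change is larger in count than that step, so a somewhat bigger movement cannot be ruled out, yet nothing measured here points to one. Compound 3 is therefore expected to fall close to compound 2, with a step of a 1.4-fold lower number from compound 2 to compound 3 (0.15 log units; within the scatter), at most a small decrease within or just beyond the scatter. The estimate for compound 3 is 3000 nM, with a range from 1000 nM to 9000 nM.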

Compound 3, solubility: 4200 nM
The estimate for compound 3 lay 1.4-fold (0.15 log units) below the measured number; measured number inside the range.
By their numbers in this assay, from the lowest: compounds 1, 2 and 3 (each within the scatter of the next).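

On the saturated chain carbon bound to an aromatic carbon, 3-(trifluoromethyl)phenyl in place of 4-fluorophenyl gives no change at the digits printed from compound 2 to compound 3 (within the scatter) in this assay, so the read-out stays flat for a change larger in heavy-atom count than the hydrogen-for-chloro step. 3-(Trifluoromethyl)phenyl in place of 2-chloro-4-fluorophenyl likewise gives no change at the digits printed from compound 1 to compound 3 (within the scatter), so all three aryl groups at this place read alike, and no compound shown goes against that. No evidence on hand bears on this result.

As far as these compounds go, all three aryl groups are fluorine-bearing phenyl groups, so it remains open whether a carboxylic acid or a morpholine on that phenyl group would move the read-out. Also open, from the compounds shown here alone, is whether the same flat reading would hold with a longer chain in the furanylmethyl amine part.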